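This account rests on a few compounds, and the source may have more. Where it says the series, first, only, none or still open, it means among the compounds named here.

Measured so far in a functional assay on MDA-MB-231 cells (Homo sapiens) for antiproliferative activity, read by MTT assay, with a stated time of 48 h; a higher number here means a weaker inhibitor, a lower number a stronger inhibitor:

Compound 1 `COc1ccc2nc(Nc3ccnc(Nc4ccc(S(N)(=O)=O)cc4)n3)sc2c1` — 6240 nM
Compound 2 `Cc1cnc(Nc2ccc(Cl)cc2)nc1Nc1nc2ccccc2s1` — its value is a limit, > 50000 nM, with no number behind it
Compound 3 `Cc1ccc2nc(Nc3ccnc(Nc4ccc(S(C)(=O)=O)cc4)n3)sc2c1` — 4440 nM

Among the two numbers, compound 1 stands highest; the nearest is compound 3, whose number lies within the scatter of compound 1, so no order between them is claimed. For compound 2 only a limit is reported (the limit of > 50000 nM in this assay, at which 1 of the 3 values shown sits).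

The step under study goes from compound 1 to compound 4 `NS(=O)(=O)c1ccc(Nc2nccc(Nc3nc4ccc(F)cc4s3)n2)cc1`. The change is fluoro in place of methoxy on an aromatic carbon. Among the compounds with values here, no step between measured compounds touches this place, so nothing on the shared core measured here shows how a fluoro in place of a methoxy on that ring moves the number.

With no guide from the data, the expected step from compound 1 to compound 4 is none beyond the scatter, that is a 1.0-fold lower number from compound 1 to compound 4 (0.02 log units; within the scatter). Compound 4 is therefore estimated at 6000 nM, with a range from 2500 nM to 15000 nM.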

Compound 4, half-maximal inhibitory concentration: 1800 nM
Beside the measured number, compound 4's estimate is 3.3-fold (0.52 log units) above it; the whole stated range lies above it.
By their numbers in this assay, from the lowest: compound 4; then compounds 3 and 1 (each within the scatter of the next). At a limit, above all of these: compound 2.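

In this assay, fluoro in place of methoxy on this aromatic carbon gives a 3.5-fold lower number from compound 1 to compound 4 (0.54 log units; beyond the scatter), a modest step. The earlier compounds shown here offered no step at this place, and this first reading shows that the number responds to the group here while the rest of compound 1 stays unchanged. Nothing shown gives a reason for the size or direction of this step.

A single step cannot tell whether the lower number comes from the arrival of fluoro or the departure of methoxy, and a plain hydrogen, a chloro, a trifluoromethyl or an amine on the same carbon of the shared core would help separate the two. From the compounds shown here alone, whether the same change would move the number in the same way on another core also stays open.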